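A few compounds are considered here, and "the series" means these few. Any claim that something is new, unique, unknown or untested is made for them only; others in the source may bear on it.

In a functional assay on A549 cells (Homo sapiens) for inhibition, read by MTT assay, with a stated time of 72 h (a higher number here means a weaker inhibitor, a lower number a stronger inhibitor), compound 1 `COC(=O)c1ccc(-n2cc(CCCC(=S)Nc3ccc(C)cc3)nn2)cc1` gives 7900 nM. Compound 2 `COC(=O)c1ccc(-n2cc(CCCC(=O)Oc3ccc(C)cc3)nn2)cc1` reaches only a limit, > 100000 nM. Compound 3 `COC(=O)c1ccc(-n2cc(CCCNC(=O)c3ccc(C)cc3)nn2)cc1` also has only a limit, > 100000 nM, and so has no number as a starting point. Compound 4 `COC(=O)c1ccc(-n2cc(CCCNC(=S)c3ccc(C)cc3)nn2)cc1` differs from compound 3 by one change, a group of 9 heavy atoms (8 carbon, 1 sulfur; one six-membered aromatic ring of carbon only) in place of a group of 9 heavy atoms (8 carbon, 1 oxygen; one six-membered aromatic ring of carbon only), on an amine nitrogen: a group with sulfur replaces a group with oxygen, on an amine nitrogen. For the measured compounds named here, no measured pair isolates this change, so the expectation rests on compound 1, the only measured compound holding sulfur, at 7900 nM. A gain in potency beyond the scatter is expected in this assay, with the estimated change an at least 6.6-fold lower number from compound 3 to compound 4 (0.82 log units; beyond the scatter). For compound 4 the estimated value is 15000 nM, with an expected range of 3000 nM to 100000 nM.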

Compound 4, half-maximal inhibitory concentration: > 100000 nM
Compound 4: no number, only a limit; the forecaster's own chance of this, stated with the estimate: 30%; middle value at least 6.6-fold (0.82 log units) away from the limit.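

No step can be read from compound 3 to compound 4: in this assay both values are limits. On these data alone, whether the group with sulfur, in place of the group with oxygen on this amine nitrogen, changes potency at all stays open.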